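The source may report more compounds than this note shows. Statements on the series, on what has been measured and on what is new or still open speak of the compounds shown alone.

Measured so far:
compound 1 `O=c1[nH]cc(S(=O)(=O)Nc2ccccc2-c2cn(-c3ccc(F)cc3)nn2)c(=O)[nH]1` — in a functional assay on HepG2 cells (Homo sapiens) for antiproliferative activity, read by MTT assay, with a stated time of 24 h (a lower number here means a stronger inhibitor, a higher number a weaker inhibitor), compound 1 gives only a limit, > 20000 nM.
compound 2 `O=c1[nH]cc(S(=O)(=O)Nc2cccc(-c3cn(-c4ccccc4)nn3)c2)c(=O)[nH]1` — in this assay compound 2 gives 11200 nM.
compound 3 `O=c1[nH]cc(S(=O)(=O)Nc2ccc(-c3cn(-c4ccccc4)nn3)cc2)c(=O)[nH]1` — in this assay compound 3 gives 18000 nM.

All three share the same sulfonamide core and differ in how the triazole is placed on the aniline ring and in the substituent on the phenyl that sits on the triazole. Compound 3 and compound 2 lie within the scatter of each other, so no order between them is claimed. Compound 1 sits at a limit of the assay (the limit of > 20000 nM in this assay, at which 1 of the 3 values shown sits), and nothing beyond that is read from it.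

Compound 4 `O=c1[nH]cc(S(=O)(=O)Nc2ccc(-c3cn(-c4ccccc4F)nn3)cc2)c(=O)[nH]1` is the next member. Its change from compound 3 is fluoro in place of hydrogen on an aromatic carbon. Within the data shown here, no measured pair in this set carries the same change, so there is no step to lean on; the only neighbouring data are compound 2 and compound 3, which are close to one another.

With nothing in the series to point either way, the expectation for compound 4 is a step from compound 3 of about a 1.1-fold lower number from compound 3 to compound 4 (0.05 log units; within the scatter), that is, none beyond the scatter. The estimate for compound 4 in this assay is therefore 16000 nM, with a range from 6000 nM to 40000 nM, and a fair chance that only a limit is reported.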

Compound 4, half-maximal inhibitory concentration: > 20000 nM
Compound 4 ended at the assay's limit (the forecaster's own chance of this, stated with the estimate: 30%); middle value at least 1.2-fold (0.09 log units) away from the limit.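

The change from phenyl to 2-fluorophenyl, with fluoro on an aromatic carbon ortho to a large group, gives the series its first measured step at this position in this assay: an at least 1.1-fold higher number from compound 3 to compound 4 (0.04 log units; that floor lies within the scatter). This step ends at a limit of the assay, so it fixes no size, and it shows only that this fluoro brings no move to a lower number. Compounds at the limit now make up a larger share of the series: the limit of > 20000 nM in this assay, at which 2 of the 4 values shown sit.

Whether the step truly reaches beyond the scatter cannot be told, and the compounds shown do not say how an amine, a carboxylic acid or a methoxy group would fare on the same phenyl in place of fluoro. Compound 1 also carries fluoro but differs from compound 4 in more than one place, so that pair gives no reading of where fluoro is tolerated on this phenyl.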